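Aryl Back on the Sulfonyl Sulfur of a Shared Core

A few compounds are considered here, and "the series" means these few. Any claim that something is new, unique, unknown or untested is made for them only; others in the source may bear on it.

Compound 3 `CCOC(=O)c1cnc2ccc(-c3cnc(OC)c(NS(C)(=O)=O)c3)cn12` carries a methanesulfonamido group on the shared core. In a functional assay on MDA-MB-231 cells (Homo sapiens) for antiproliferative activity, read by sulforhodamine B assay, with a stated time of 72 h (on this read-out higher numbers stand for weaker inhibition and lower numbers for stronger inhibition), compound 3 gives 190 nM. That number sits alongside the other two: compound 1 `CCOC(=O)c1cnc2ccc(-c3cnc(OC)c(NS(=O)(=O)c4ccc(F)cc4F)c3)cn12` gives 120 nM and compound 2 `COc1ncc(-c2ccc3ncc(C(=O)O)n3c2)cc1NS(=O)(=O)c1ccc(F)cc1F` gives 370 nM, and the gap from compound 3 to each of them lies within the usual scatter. Compound 4 `CCOC(=O)c1cnc2ccc(-c3cnc(OC)c(NS(=O)(=O)c4ccc(F)cc4)c3)cn12` differs from compound 3 in one place: 4-fluorophenyl in place of methyl on a sulfonyl sulfur. Among the compounds with values here, two measured steps bear on this. a 1.6-fold higher number from compound 1 to compound 3 (0.20 log units; within the scatter), and a 3.1-fold higher number from compound 1 to compound 2 (0.49 log units; beyond the scatter); the second concerns the ester and speaks only to the spread of the series. The change to compound 4 largely reverses the first step, returning an aryl group to the sulfonyl sulfur, with 4-fluorophenyl where compound 1 bears 2,4-difluorophenyl. On that basis the expected step for compound 4 is a 1.5-fold lower number from compound 3 to compound 4 (0.16 log units; within the scatter), a move back toward the number of compound 1 that does not rise above the scatter. Compound 4 is estimated at 130 nM, between 60 nM and 300 nM.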

Compound 4, half-maximal inhibitory concentration: 530 nM
The estimate for compound 4 lay 4.1-fold (0.61 log units) below the measured number; measured number above the stated range.
By their numbers in this assay, from the lowest: compounds 1, 3, 2 and 4 (each within the scatter of the next, the first and the last beyond it).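

On the sulfonyl sulfur, an aryl group alone does not restore the number of compound 1: in this assay, 4-fluorophenyl in place of methyl gives a 2.8-fold higher number from compound 3 to compound 4 (0.45 log units; beyond the scatter) and not a move back toward compound 1. Hydrogen in place of fluoro on an aromatic carbon gives a 4.4-fold higher number from compound 1 to compound 4 (0.65 log units; beyond the scatter) beyond the scatter, whereas replacing the whole 2,4-difluorophenyl with methyl gave a 1.6-fold higher number from compound 1 to compound 3 (0.20 log units; within the scatter) and so stayed within it. Nothing available accounts for this behaviour.

The compounds shown leave open how unsubstituted phenyl or a longer chain such as propyl on the sulfonyl sulfur would read. They also leave open whether a carboxylic acid in place of the ethyl ester would shift the number in the same way with 4-fluorophenyl or methyl on the sulfonyl sulfur.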